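The source may hold more compounds than are shown below. What is called first, only, known or untested is meant among the compounds shown, and "the series" means these compounds.

Compound 1 `CN1C(=O)C2(C(C#N)=C(N)Oc3cc4oc(-c5ccccc5)cc(=O)c4c(O)c32)c2ccccc21`: in a functional assay on K562 cells (Homo sapiens) for antiproliferative activity, read by MTT assay, with a stated time of 48 h (a higher number here means a weaker inhibitor, a lower number a stronger inhibitor), compound 1 gives > 50000 nM, which is a limit of the assay rather than a number.
Compound 2 `CN1C(=O)C2(C(C#N)=C(N)Oc3cc4oc(-c5ccccc5)cc(=O)c4c(O)c32)c2cc(Cl)ccc21`: in this assay compound 2 gives 4340 nM.
Compound 3 `COc1ccc2c(c1)C1(C(=O)N2Cc2ccccc2)C(C#N)=C(N)Oc2cc3oc(-c4ccccc4)cc(=O)c3c(O)c21`: in this assay compound 3 gives > 50000 nM, again only a limit of the assay.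

From the compounds shown here alone, compound 3 thus stands at the limit of > 50000 nM in this assay, at which 2 of the 3 values shown sit, so its true number is unknown. Compound 4 `N#CC1=C(N)Oc2cc3oc(-c4ccccc4)cc(=O)c3c(O)c2C12C(=O)N(Cc1ccccc1)c1ccc(Cl)cc12` differs from compound 3 by chloro in place of methoxy on an aromatic carbon. Within the data shown here, one measured step bears on this change, since it also brought in a chloro group: an at least 11-fold lower number from compound 1 to compound 2 (1.06 log units; beyond the scatter), a large lowering of the number. A lowering in the same direction is therefore expected here, although the starting point is only a limit. Compound 4 is expected to give 8000 nM, with a likely range from 2000 nM to 50000 nM. This amounts to an expected at least 6.2-fold lower number from compound 3 to compound 4 (0.79 log units; beyond the scatter).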

Compound 4, half-maximal inhibitory concentration: 36300 nM
The estimate for compound 4 lay 4.5-fold (0.66 log units) below the measured number; the measured number falls inside the stated range.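

Chloro in place of methoxy on this aromatic carbon gives an at least 1.3-fold lower number from compound 3 to compound 4 (0.13 log units; that floor lies within the scatter), so the true size of this change cannot be read. Compound 3 gives only a limit of the assay: the limit of > 50000 nM in this assay, at which 2 of the 4 values shown sit. With chloro kept on the ring, phenyl in place of hydrogen on the saturated chain carbon bound to an amide-type nitrogen in a ring gives an 8.4-fold higher number from compound 2 to compound 4 (0.92 log units; beyond the scatter), so a change at this second place clearly alters the number.

From the compounds shown here alone, it remains open how an amine on the same aromatic carbon would fare. A longer chain in place of the phenyl also remains untested among the compounds shown.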